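A Second Chloro on the Aromatic Ring

A few compounds are considered here, and "the series" means these few. Any claim that something is new, unique, unknown or untested is made for them only; others in the source may bear on it.

In a functional assay on the whole organism for antagonist activity, with Mus musculus as the target, in the maximal electroshock model (on this read-out lower numbers stand for an effect already at smaller amounts and higher numbers for an effect only at larger amounts of compound), compound 1 `COC(=O)NC1=NC(c2cccc(Cl)c2)CN1` gives 48 mg/kg, while compound 2 `COC(=O)NC1=NC(c2cccc(Cl)c2)CN1C` gives 100 mg/kg. Compound 2 thus has the higher of the two numbers and needs the larger dose for its effect. The two compounds are separated by methyl in place of hydrogen on an amine nitrogen in a ring, and the measured step is a 2.1-fold higher number from compound 1 to compound 2 (0.32 log units; beyond the scatter).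

Compound 3 `COC(=O)NC1=NC(c2cc(Cl)cc(Cl)c2)CN1C` keeps that methyl and differs from compound 2 by chloro in place of hydrogen on an aromatic carbon, meta to a chloro group: chloro in place of hydrogen on an aromatic carbon. Among the measured compounds shown here, no measured step covers a change on the aromatic ring, so the step of a 2.1-fold higher number from compound 1 to compound 2 (0.32 log units; beyond the scatter) offers only a rough guide to size, and none to direction. For the measured compounds named here, a small shift in this assay, no larger than that step and probably within the scatter, is therefore expected, with a slight lean towards a lower number. The estimated step is a 1.2-fold lower number from compound 2 to compound 3 (0.07 log units; within the scatter). For compound 3 the estimated value is 85 mg/kg, with an expected range from 35 mg/kg to 200 mg/kg.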

Compound 3, dose for half-maximal effect: 44 mg/kg
Estimate against measurement, compound 3: 1.9-fold (0.29 log units) above; low and high end bracket the measured number.
By their numbers in this assay, from the lowest: compounds 3 and 1 (each within the scatter of the next); then compound 2.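

In this assay the aromatic ring now has a measured step of its own: chloro in place of hydrogen on an aromatic carbon, meta to a chloro group, gives a 2.3-fold lower number from compound 2 to compound 3 (0.36 log units; beyond the scatter) and so moves the number towards smaller doses. The only earlier step (a 2.1-fold higher number from compound 1 to compound 2 (0.32 log units; beyond the scatter)) concerned the amine nitrogen in the ring and ran the other way, so the compounds shown now hold one single change that raises the number and another, at a different place, that lowers it. No supporting data bear on the origin of the new step.

What the compounds leave open is whether this lower number belongs to chloro in particular or would also appear with another group at the same place, such as fluoro, methyl or methoxy. Also open, on these data alone, is whether the second chloro would give a step of similar size and the same direction on compound 1, where the ring nitrogen carries hydrogen instead of methyl.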